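Halogen swap on the fused ring: outlook for compound 3

This account rests on a few compounds, and the source may have more. Where it says the series, first, only, none or still open, it means among the compounds named here.

Compound 1, `Cc1cc(C)cc(NC(=O)COc2cc(C)nc3ccccc23)c1`, in a toxicity assay on HepG2 cells (Homo sapiens) for inhibition, read by CellTiter-Glo, with a stated time of 48 h; on this read-out lower numbers stand for stronger inhibition and higher numbers for weaker inhibition: > 100000 nM (a limit of the assay, not a number).
Compound 2, `Cc1cc(C)cc(NC(=O)COc2cc(C)nc3ccc(F)cc23)c1`, in this assay: 63100 nM.

Compound 1 reports only a limit in this assay, > 100000 nM, and so contributes no number. Within the data shown here, compound 2 gives 63100 nM, which is the only number the series shows in this assay. Among the measured compounds shown here, the one further value shown belongs to compound 1 and is a limit. The measured step of an at least 1.5-fold lower number from compound 1 to compound 2 (0.19 log units; that floor lies within the scatter) can be given only as a floor, because the limit of > 100000 nM in this assay, at which 1 of the 2 values shown sits, leaves one end of it open, and that floor lies within the scatter.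

Compound 3, `Cc1cc(C)cc(NC(=O)COc2cc(C)nc3ccc(Cl)cc23)c1`, is obtained from compound 2 by chloro in place of fluoro on an aromatic carbon. For the measured compounds named here, the only measured step touching this position is an at least 1.5-fold lower number from compound 1 to compound 2 (0.19 log units; that floor lies within the scatter); it exchanges halogen for hydrogen rather than one halogen for another, and it does not exceed the scatter. No step beyond the scatter is therefore expected in this assay for the exchange of fluoro for chloro. Compound 3 is estimated at 45000 nM, with a range from 15000 nM to 100000 nM. This estimate means an expected step of a 1.4-fold lower number from compound 2 to compound 3 (0.15 log units; within the scatter).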

Compound 3, half-maximal inhibitory concentration: > 100000 nM
Compound 3 ended at the assay's limit (the forecaster's own chance of this, stated with the estimate: 25%); middle value at least 2.2-fold (0.34 log units) from the limit.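

Compound 3 reports > 100000 nM in this assay, a limit of the assay and not a number. Among these compounds, exchanging fluoro for chloro on this aromatic carbon gives an at least 1.5-fold higher number from compound 2 to compound 3 (0.19 log units; that floor lies within the scatter), so a halogen at this carbon does not by itself bring a compound to a readable number, and compound 2, with fluoro, remains the only one of the three compounds with a number in this read-out. The step from hydrogen to chloro between compound 1 and compound 3 cannot be read, and the fluoro to chloro step stays open at one end, because the values of compound 1 and compound 3 are both limits: the limit of > 100000 nM in this assay, at which 2 of the 3 values shown sit.

Whether any group on this aromatic carbon produces a step beyond the scatter stays open, as no readable step shown here does so. Also open, on these data alone, is how a methoxy group, an amine or a nitrile on the same carbon would read in this assay, and whether a number well clear of the limit can be reached on the shared core at all.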